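A few compounds are considered here, and "the series" means these few. Any claim that something is new, unique, unknown or untested is made for them only; others in the source may bear on it.

In an ADME assay on HFF cells (Homo sapiens) for cytotoxicity, with a stated time of 8 days (on this read-out higher numbers stand for lower toxicity in this test and lower numbers for higher toxicity in this test), the measured compounds stand as follows.

Compound 1, `CNc1nc(N)nc2c1ncn2/C=C1/CC1(CO)CO`, gives 265000 nM.
Compound 2, `COCCOc1nc(N)nc2c1ncn2/C=C1/CC1(CO)CO`, gives > 300000 nM, which is a limit of this assay rather than a number.
Compound 3, `CCCSc1nc(N)nc2c1ncn2/C=C1/CC1(CO)CO`, gives > 300000 nM, again a limit of this assay and not a number.

Compound 3 therefore stands at the top of the range the test can report, and the limit of > 300000 nM in this assay, at which 2 of the 3 values shown sit, describes where it sits. Compound 4, `CCCCCOc1nc(N)nc2c1ncn2/C=C1/CC1(CO)CO`, has not yet been measured. The change that leads to it is pentyloxy in place of propylsulfanyl on an aromatic carbon.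

Within the data shown here, two measured steps bear on this. From compound 2 to compound 3 the step is a step that the two limits leave unreadable from compound 2 to compound 3, so a change of one group on that aromatic carbon between two compounds sitting at the limit tells nothing readable. The step of an at least 1.1-fold higher number from compound 1 to compound 3 (0.05 log units; that floor lies within the scatter) is the only one with any direction, and its floor lies within the scatter. Among the measured compounds shown here, no measured step therefore points to a change beyond the scatter for this assay.

Compound 4 is accordingly expected to sit at or near the same limit, with an estimated value of 320000 nM, ranging from 150000 nM to 650000 nM. The expected step that the limit leaves unreadable from compound 3 to compound 4 is thus estimated to lie within the scatter.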

Compound 4, half-maximal cytotoxic concentration: 259000 nM
Compound 4: middle estimate off by 1.2-fold (0.09 log units), on the high side; the measured number falls inside the stated range.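

In this assay pentyloxy on this aromatic carbon gives a measured number rather than a limit, so the position now carries a second readable value, and the exchange for methylamino is a step of a 1.0-fold lower number from compound 1 to compound 4 (0.01 log units; within the scatter). Against the two compounds held at the limit, the steps are an at least 1.1-fold lower number from compound 3 to compound 4 (0.06 log units; that floor lies within the scatter) and an at least 1.1-fold lower number from compound 2 to compound 4 (0.06 log units; that floor lies within the scatter); both floors lie within the scatter, so neither shows how far the number truly moved. Thus neither the change of the linking atom from sulfur to oxygen together with the longer chain nor the replacement of the methoxy end by propyl gives a step beyond the scatter, and what can be read stays bounded by the values that are only limits: the limit of > 300000 nM in this assay, at which 2 of the 4 values shown sit.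

The compounds shown leave open whether a longer chain than pentyloxy, a benzyloxy group or a carboxylic acid at the end of the chain on this carbon would bring the number down beyond the scatter. On these data alone, the step between the two compounds held at the limit cannot be read, so how they stand against each other also remains open.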